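Rearranged hydroxyurea on the dipropoxy anilide core

The source may report more compounds than this note shows. Statements on the series, on what has been measured and on what is new or still open speak of the compounds shown alone.

Compound 1 `CCCNC(=O)N(O)c1cc([C@H]2CC[C@H](c3cc(OC)c(OC)c(OC)c3)O2)cc(OCCC)c1OCCC`: 3000 nM
Compound 2 `CCCOc1c(NC(=O)N(O)CCC)cc(C2CCC(c3cc(OC)c(OC)c(OC)c3)O2)cc1OC`: 10000 nM; 10000 nM (2 entries)
Compound 3 `CCCOc1c(NC(=O)N(O)C2CCCCC2)cc(C2CCC(c3cc(OC)c(OC)c(OC)c3)O2)cc1OC`: 2540 nM

In a functional assay on RBL-2H3 cells for inhibition of Polyunsaturated fatty acid 5-lipoxygenase (Rattus norvegicus) (on this read-out higher numbers stand for weaker inhibition and lower numbers for stronger inhibition), compound 1 gives 3000 nM, the highest of the two single numbers in the set. Compound 3 gives 2540 nM in this assay, a gap from compound 1 that stays within the usual scatter, so the two cannot be ordered. Compound 2 sits apart with 10000 nM; 10000 nM (2 entries) in this assay, recorded twice with the same outcome.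

Compound 4 `CCCOc1cc([C@H]2CC[C@H](c3cc(OC)c(OC)c(OC)c3)O2)cc(N(CC)C(=O)N(O)CC)c1OCCC` is not yet measured. It differs from compound 1 in one place: ethyl(ethyl(hydroxy)carbamoyl)amino in place of hydroxy(propylcarbamoyl)amino on an aromatic carbon. Among the compounds with values here, no pair of measured compounds traces this exact change, so the step has no precedent here. Compound 4 is expected to land close to compound 1, with a 1.7-fold higher number from compound 1 to compound 4 (0.22 log units; within the scatter) as the estimated step, not beyond the scatter in either direction. The estimate for compound 4 in this assay is 5000 nM, with a range from 1500 nM to 15000 nM.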

Compound 4, half-maximal inhibitory concentration: 1340 nM
Beside the measured number, compound 4's estimate is 3.7-fold (0.57 log units) above it; measured number below the stated range.
By their numbers in this assay, from the lowest: compounds 4, 3 and 1 (each within the scatter of the next, the first and the last beyond it).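

In this assay, putting ethyl(ethyl(hydroxy)carbamoyl)amino in place of hydroxy(propylcarbamoyl)amino, on the aromatic carbon ortho to a propoxy group, gives a 2.2-fold lower number from compound 1 to compound 4 (0.35 log units; beyond the scatter), a modest step beyond the scatter toward stronger inhibition. Within the data shown here, it is the only step in this set that can be read, and it shows that this position accepts the larger entering group, with its ethyl on each nitrogen, without any loss of inhibition. No measurement at hand accounts for the step.

From the compounds shown here alone, this single step changes both nitrogens at once, so it remains open whether the gain belongs to the ethyl on the nitrogen attached to the ring or to the change at the other nitrogen. Going by these compounds, how a methyl or a butyl on either nitrogen would fare also remains open.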